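Ethyl gives way to formyl in compound 3

The compounds below may be only part of what the source reports. "The series", "measured", "known", "first", "only" and "open" are said of these compounds alone.

Of the compounds shown here, two have been read in a functional assay on cells (Homo sapiens) for antiproliferative activity, read by WST assay, with a stated time of 3 days; on this read-out lower numbers stand for stronger inhibition and higher numbers for weaker inhibition. Compound 1 `O=Cc1cc(=O)[nH]c(=O)n1[C@@H]1O[C@H](CO)[C@@H](O)[C@H]1O` returns only a limit, > 50000 nM. For the measured compounds named here, compound 2 `CCc1c(F)c(=O)[nH]c(=O)n1[C@@H]1O[C@H](CO)[C@@H](O)[C@H]1O` gives 1400 nM, the only actual number so far. Compound 3 `O=Cc1c(F)c(=O)[nH]c(=O)n1[C@@H]1O[C@H](CO)[C@@H](O)[C@H]1O` keeps the fluoro group of compound 2 and carries formyl in place of ethyl on an aromatic carbon. Going by the values given here, no measured step isolates this change. With a formyl group and no fluoro group, compound 1 stands at the limit of > 50000 nM, so some loss is expected, though perhaps not all the way to that limit. The expected change in this assay is a weakening beyond the usual scatter, an estimated step of a 4.3-fold higher number from compound 2 to compound 3 (0.63 log units; beyond the scatter). For compound 3 the estimated value is 6000 nM, within an expected range of 1000 nM to 40000 nM.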

Compound 3, half-maximal inhibitory concentration: 400 nM
Compound 3: middle estimate off by 15-fold (1.18 log units), on the high side; measured number below the stated range.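

In this assay, formyl on this aromatic carbon, next to the ring nitrogen and ortho to a fluoro group, is no drawback when the fluoro group is kept: replacing ethyl with formyl gives a 3.5-fold lower number from compound 2 to compound 3 (0.54 log units; beyond the scatter) and so improves on the ethyl compound. With formyl held constant, fluoro in place of hydrogen gives an at least 120-fold lower number from compound 1 to compound 3 (2.09 log units; beyond the scatter) in the same assay, so formyl alone does not account for the weak reading of compound 1. For the compounds shown here, the size of that step is bounded by a limit, the one for compound 1: the limit of > 50000 nM in this assay, at which 1 of the 3 values shown sits.

The compounds shown leave open whether fluoro in place of hydrogen would matter as much alongside ethyl as it does alongside formyl. They also do not show how a hydroxymethyl group, a carboxylic acid or a longer chain on that carbon would compare with formyl.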